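A few compounds are considered here, and "the series" means these few. Any claim that something is new, unique, unknown or untested is made for them only; others in the source may bear on it.

The measured compounds:
Compound 1 `COc1ccc(C(=O)CSc2nc(C(c3ccccc3)c3ccccc3)c(C)c(=O)[nH]2)cc1` gives in an ADME assay on MT4 cells (Homo sapiens) for cytotoxicity (a lower number here means that less compound is tolerated, a higher number that more compound is tolerated), only a limit, > 274000 nM.
Compound 2 `Cc1c(Cc2cccc3ccccc23)nc(SCC(=O)c2ccccc2)[nH]c1=O` gives in this assay only a limit, >= 305000 nM.
Compound 3 `CCc1c(Cc2ccc(-c3ccccc3)cc2)nc(SCC(=O)c2ccc(OC)cc2)[nH]c1=O` gives in this assay only a limit, > 266000 nM.

Compound 1 therefore has no fixed place among these numbers: its own value is a limit of the assay, and the two further values shown are limits as well, so none of the three compounds can be ranked against another. The limits sit at slightly different points (the limit of > 266000 nM in this assay, at which 1 of the 3 values shown sits, (the limit of > 274000 nM in this assay, at which 1 of the 3 values shown sits), (the limit of >= 305000 nM in this assay, at which 1 of the 3 values shown sits)), and nothing more than that can be read from them.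

Compound 4 `CCc1c(C(c2ccccc2)c2ccccc2)nc(SCC(=O)c2ccc(OC)cc2)[nH]c1=O` has not yet been measured. It differs from compound 1 by methyl in place of hydrogen on a saturated chain carbon bound to an aromatic carbon; seen one bond further out, the same change reads methyl to ethyl. Among the measured compounds shown here, no step between measured compounds that differ in one place is available, so no measured step bears on this change. Because compound 1 sits at > 274000 nM the account expects no step beyond the usual scatter from compound 1 to compound 4, that is a number no higher from compound 1 to compound 4 (the limit leaves the size open). Compound 4 is expected to give in this assay about 274000 nM, within a range from 140000 nM to 400000 nM, and most probably again only a limit rather than a number.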

Compound 4, half-maximal cytotoxic concentration: > 266000 nM
Compound 4 was reported as a limit; the forecaster's own chance of this, stated with the estimate: 85%; the middle value is on the limit's open side.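

In this assay compound 4 gives only a limit, > 266000 nM. Among the compounds shown here, the value of compound 1 is also only a limit, so no step from compound 1 to compound 4 can be read. The compounds shown leave open how much of any of them is tolerated in this assay, and whether methyl in place of hydrogen on a saturated chain carbon bound to an aromatic carbon changes that.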